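A few compounds are considered here, and "the series" means these few. Any claim that something is new, unique, unknown or untested is made for them only; others in the source may bear on it.

Series notes, values in a functional assay on SAOS-2 cells (Homo sapiens) for antiproliferative activity, read by MTT assay, with a stated time of 72 h; on this read-out higher numbers stand for weaker inhibition and lower numbers for stronger inhibition:

- compound 1 `O=C(C1=C(O)C(=O)N(CCCn2ccnc2)C1c1ccc(Br)cc1)c1ccccc1`: 31600 nM
- compound 2 `O=C(C1=C(Nc2ccc(F)cc2)C(=O)N(CCCn2ccnc2)C1c1ccc(Br)cc1)c1ccccc1`: 32700 nM
- compound 3 `O=C(C1=C(Nc2ccc(OC(F)(F)F)cc2)C(=O)N(CCCn2ccnc2)C1c1ccc(Br)cc1)c1ccccc1`: 17900 nM

Compound 3 carries the (4-(trifluoromethoxy)phenyl)amino group on the double-bonded ring carbon where compound 1 carries hydroxy and compound 2 the (4-fluorophenyl)amino group. Its position among the three is unremarkable: a 1.8-fold lower number from compound 1 to compound 3 (0.25 log units; within the scatter) and a 1.8-fold lower number from compound 2 to compound 3 (0.26 log units; within the scatter) are both within the scatter, as is a 1.0-fold higher number from compound 1 to compound 2 (0.01 log units; within the scatter), so the three measured compounds cannot be separated in this assay.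

The next compound, compound 4 `O=C(C1=C(Nc2cccc(Br)c2)C(=O)N(CCCn2ccnc2)C1c1ccc(Br)cc1)c1ccccc1`, differs from compound 3 in one place: 3-bromophenyl in place of 4-(trifluoromethoxy)phenyl on an amine nitrogen. Among the measured compounds shown here, no measured step exchanges one aryl group on that amine nitrogen for another; the nearest relevant steps are the aryl swap from compound 2 to compound 3 and the two hydroxy-to-arylamino steps, and none of them moved the read-out beyond the scatter. On that basis compound 4 is expected to stay close to compound 3, with a 1.2-fold higher number from compound 3 to compound 4 (0.09 log units; within the scatter) as the estimated step and no direction beyond the scatter. The estimate for compound 4 in this assay is 22000 nM, range 9000 nM to 55000 nM.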

Compound 4, half-maximal inhibitory concentration: 9090 nM
Compound 4: middle estimate off by 2.4-fold (0.38 log units), on the high side, and the stated range covers the measured number.
By their numbers in this assay, from the lowest: compounds 4, 3, 1 and 2 (each within the scatter of the next, the first and the last beyond it).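

In this assay the amine position gives its first steps beyond the scatter: 3-bromophenyl in place of 4-fluorophenyl on the amine nitrogen (a 3.6-fold lower number from compound 2 to compound 4 (0.56 log units; beyond the scatter)) and (3-bromophenyl)amino in place of hydroxy (a 3.5-fold lower number from compound 1 to compound 4 (0.54 log units; beyond the scatter)), both modest. The aryl group on that nitrogen can therefore move the read-out, and an arylamino group in place of hydroxy does not always leave it within the scatter, although the swap from 4-(trifluoromethoxy)phenyl remains within it (a 2.0-fold lower number from compound 3 to compound 4 (0.29 log units; within the scatter)). Nothing measured here accounts for these steps.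

Compound 4 differs from compound 2 in both the halogen and its printed ring position, so the two contributions cannot be separated. A 4-bromophenyl, 3-chlorophenyl or unsubstituted phenyl group on the amine nitrogen would address that question.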